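Methoxycarbonyl for fluoro on the fused carbocyclic ring

The source may hold more compounds than are shown below. What is called first, only, known or untested is meant among the compounds shown, and "the series" means these compounds.

Compound 2 `Cc1c(C(=O)Nc2ccc(Oc3ncnc4[nH]cc(-c5ccccc5)c34)c(F)c2)c(=O)c2cc(F)ccc2n1C` is measured in an assay on isolated protein for inhibition of tyrosine-protein kinase receptor UFO (Homo sapiens), read by FRET and Z'-LYTE, with a stated time of 1.5 h (on this read-out lower numbers stand for stronger inhibition and higher numbers for weaker inhibition), and gives only a limit, > 10000 nM. Compound 1 `Cc1c(C(=O)Nc2ccc(Oc3ncnc4[nH]cc(-c5ccccc5)c34)c(F)c2)c(=O)c2c(Cl)cccc2n1C` likewise returns only a limit, > 10000 nM. Compound 3 `CCc1ccc2c(c1)c(=O)c(C(=O)Nc1ccc(Oc3ncnc4cc(OC)c(OC)cc34)c(F)c1)c(C)n2C`, built on a different core, gives 4 nM. Among the compounds with values here, the picture is dominated by the limit of > 10000 nM in this assay, at which 2 of the 3 values shown sit, and no step between measured compounds is available. Compound 4 `COC(=O)c1ccc2c(c1)c(=O)c(C(=O)Nc1ccc(Oc3ncnc4[nH]cc(-c5ccccc5)c34)c(F)c1)c(C)n2C` is not yet measured; it differs from compound 2 by methoxycarbonyl in place of fluoro on an aromatic carbon. Both compounds sharing the core of compound 2 stop at the limit of > 10000 nM in this assay, at which 2 of the 3 values shown sit, so no step beyond the scatter is expected from this change, and a limit read-out remains the likelier outcome. Compound 4 is estimated at 9000 nM, within 1500 nM to 40000 nM. The step this implies is expected to be an at least 1.1-fold lower number from compound 2 to compound 4 (0.04 log units; that floor lies within the scatter).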

Compound 4, half-maximal inhibitory concentration: > 10000 nM
Compound 4: a limit, no number; the forecaster's own chance of this, stated with the estimate: 60%; middle value at least 1.1-fold (0.04 log units) from the limit.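

Compound 2 and compound 4 both end at a limit rather than a number in this assay, so no step between them can be read: the limit of > 10000 nM in this assay, at which 3 of the 4 values shown sit.

The compounds shown leave open whether methoxycarbonyl and fluoro differ at all on this core.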